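The compounds below may be only part of what the source reports. "The series", "measured", "known", "first", "only" and "open" are said of these compounds alone.

Measured in a functional assay on A549 cells (Homo sapiens) for antiproliferative activity, read by MTT assay, with a stated time of 48 h; on this read-out higher numbers stand for weaker inhibition and lower numbers for stronger inhibition:
- Compound 1 `C/C(=C\CC/C(C)=C/CC[C@@H]1[C@@]2(C)CCC(=O)C(C)(C)[C@H]2CC[C@@]1(C)O)CC/C=C(\C)C(=O)OCc1cn(-c2ccc(F)cc2)nn1`: > 150000 nM (a limit)
- Compound 2 `C/C(=C\CC/C(C)=C/CC[C@@H]1[C@@]2(C)CCC(=O)C(C)(C)[C@H]2CC[C@@]1(C)O)CC/C=C(\C)C(=O)OCc1cn(-c2ccccc2C(F)(F)F)nn1`: > 150000 nM (a limit)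
- Compound 3 `C/C(=C\CC/C(C)=C/CC[C@@H]1[C@@]2(C)CCC(=O)C(C)(C)[C@H]2CC[C@@]1(C)O)CC/C=C(\C)C(=O)OCc1cn(-c2ccc(F)c(Cl)c2)nn1`: > 150000 nM (a limit)

Compound 1 gives only a limit and not a number, and its two relatives share that position: the limit of > 150000 nM in this assay, at which 3 of the 3 values shown sit.

Compound 4 `C#CCOC(=O)/C(C)=C/CC/C(C)=C/CC/C(C)=C/CC[C@@H]1[C@@]2(C)CCC(=O)C(C)(C)[C@H]2CC[C@@]1(C)O` differs from compound 1 by a larger change: ethynyl in place of 1-(4-fluorophenyl)-1H-1,2,3-triazol-4-yl on a saturated chain carbon bound to an oxygen next to a carbonyl group. In words, this is ethynyl in place of 1-(4-fluorophenyl)-1H-1,2,3-triazol-4-yl on a saturated chain carbon bound to an oxygen next to a carbonyl group.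

Three measured steps lie nearby: a step that the two limits leave unreadable from compound 1 to compound 2, a step that the two limits leave unreadable from compound 1 to compound 3 and a step that the two limits leave unreadable from compound 2 to compound 3. None has a readable size, and all three keep the triazole and alter only what sits on its phenyl ring. They therefore give no measured size for removing the whole group.

In this assay, within the data shown here, no step in a definite direction is expected, and a result close to the same limit seems most likely. The estimated step is a number no higher from compound 1 to compound 4 (the limit leaves the size open). For compound 4 the estimated value is 150000 nM, with an expected range of 60000 nM to 300000 nM.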

Compound 4, half-maximal inhibitory concentration: 45100 nM
Compound 4: the middle estimate sits 3.3-fold (0.52 log units) above what was measured; the whole stated range lies above it.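

In this assay, putting ethynyl in place of 1-(4-fluorophenyl)-1H-1,2,3-triazol-4-yl gives an at least 3.3-fold lower number from compound 1 to compound 4 (0.52 log units; beyond the scatter). This shows that a change on this saturated chain carbon bound to an oxygen next to a carbonyl group can bring a compound with the same core to a measurable number. Compound 1, compound 2 and compound 3 all give only a limit, so the steps among them cannot be read: the limit of > 150000 nM in this assay, at which 3 of the 4 values shown sit.

This change removes the triazole and the fluorophenyl ring together, so the compounds shown do not tell which part goes with the lower number, and the true size of the step remains open. Going by these compounds, how a triazole carrying a methyl group instead of the phenyl ring, or a free carboxylic acid at this place, would read also stays open.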